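The source may report more compounds than this note shows. Statements on the series, on what has been measured and on what is new or still open speak of the compounds shown alone.

Four compounds are compared in an ADME assay on HEK-293T cells (Homo sapiens) for cytotoxicity, read by CCK-8 assay, with a stated time of 48 h; a higher number here means a weaker inhibitor, a lower number a stronger inhibitor. Compound 1 `O=C(NCCNS(=O)(=O)c1ccc(-c2ccccc2Oc2ccc(O)c(O)c2)s1)Nc1cc(Cl)cc(Cl)c1` and compound 2 `O=C(NCCNS(=O)(=O)c1ccc(-c2ccccc2Oc2ccc([N+](=O)[O-])c([N+](=O)[O-])c2)s1)Nc1cc(Cl)cc(Cl)c1` are built on one core, while compound 3 `O=C(NCCNS(=O)(=O)c1ccc(-c2ccccc2Oc2ccc([N+](=O)[O-])c([N+](=O)[O-])c2)s1)Nc1cc(C(F)(F)F)cc(C(F)(F)F)c1` and compound 4 `O=C(NCCNS(=O)(=O)c1ccc(-c2ccccc2Oc2ccc(O)c(O)c2)s1)Nc1cc(C(F)(F)F)cc(C(F)(F)F)c1` are built on a second; the difference between the two cores is not broken down here. In this assay compound 1 gives 12400 nM. For compound 2 the reading in this assay is > 20000 nM, which is a limit of the assay rather than a number, namely (the limit of > 20000 nM in this assay, at which 1 of the 3 values shown sits). For compound 3 the reading in this assay is > 50000 nM, again a limit and not a number, namely (the limit of > 50000 nM in this assay, at which 1 of the 3 values shown sits). Within the data shown here, the single change that has been measured, (3,4-dihydroxyphenyl in place of 3,4-dinitrophenyl on an oxygen on an aromatic ring), gives an at least 1.6-fold lower number from compound 2 to compound 1 (0.20 log units; that floor lies within the scatter). The same kind of change, (3,4-dihydroxyphenyl in place of 3,4-dinitrophenyl on an oxygen on an aromatic ring), turns compound 3 into compound 4. The measured step of an at least 1.6-fold lower number from compound 2 to compound 1 (0.20 log units; that floor lies within the scatter) has a floor that lies within the scatter, so it offers only a weak guide. On that basis a step of an at least 1.6-fold lower number from compound 3 to compound 4 (0.22 log units; that floor lies within the scatter) is expected. Compound 4 is therefore estimated to give about 30000 nM in this assay, most likely between 10000 nM and 90000 nM, with a real chance that only a limit is reported.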

Compound 4, half-maximal inhibitory concentration: 17100 nM
Beside the measured number, compound 4's estimate is 1.8-fold (0.24 log units) above it, and the stated range covers the measured number.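

In this assay the replacement of 3,4-dinitrophenyl by 3,4-dihydroxyphenyl on the second core gives (an at least 2.9-fold lower number from compound 3 to compound 4 (0.46 log units; beyond the scatter)). Set beside the same change on the first core, the size of the step cannot be compared: the same change on two cores in this assay, an at least 1.6-fold lower number (0.20 log units; that floor lies within the scatter) from compound 2 to compound 1 and an at least 2.9-fold lower number (0.46 log units; beyond the scatter) from compound 3 to compound 4; the limit leaves it open whether they differ. Both steps start from a limit of the assay rather than a number, so the pair supports at most a shared direction on these two cores, clear of the scatter only on the core of compound 3, and it does not show that the change carries a fixed size from one core to another.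

The compounds shown leave open how the series would respond if the two hydroxyl groups gave way to a single hydroxyl, to methoxy groups or to amines. They also leave open whether the same change would hold with a longer chain in the linker, or with an aryl urea bearing a carboxylic acid.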